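Swapping propyl for 4-methoxyphenyl on a shared core

A few compounds are considered here, and "the series" means these few. Any claim that something is new, unique, unknown or untested is made for them only; others in the source may bear on it.

Values in a functional assay on HCT-116 cells (Homo sapiens) for cytotoxicity, read by MTT assay, with a stated time of 48 h, in the presence of a further agent that is not named here; a lower number here means that less compound is needed, a higher number that more compound is needed for the effect:
compound 1 `COc1ccc(-c2cc(NNC(=O)Nc3cc(Cl)nc(Cl)c3)nc3c2cnn3C)cc1`: 12300 nM
compound 2 `CCCc1cc(NNC(=O)Nc2cc(Cl)nc(Cl)c2)nc2c1c(C)nn2C`: 72200 nM

Of these two, compound 2 has the higher number, so more of it is needed for the effect, and its gap to compound 1 lies beyond the usual scatter. Among the measured compounds shown here, no measured pair differs in just one place, so the effect of a single change cannot be read directly. Compound 3 `COc1ccc(-c2cc(NNC(=O)Nc3cc(Cl)nc(Cl)c3)nc3c2c(C)nn3C)cc1` departs from compound 2 in one place: 4-methoxyphenyl in place of propyl on an aromatic carbon, with 4-methoxyphenyl in place of propyl on an aromatic carbon. Compound 1 also carries 4-methoxyphenyl and gives 12300 nM, so a lower number is expected in this assay, a change beyond the scatter. The expected size of this drop is a 5.2-fold lower number from compound 2 to compound 3 (0.71 log units; beyond the scatter). For compound 3 the estimated value is 14000 nM, with an expected range from 4500 nM to 40000 nM.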

Compound 3, half-maximal effective concentration: 82300 nM
The estimate for compound 3 lay 5.9-fold (0.77 log units) below the measured number, and the stated range ends below it.
By their numbers in this assay, from the lowest: compound 1; then compounds 2 and 3 (each within the scatter of the next).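

In this assay, putting 4-methoxyphenyl in place of propyl on an aromatic carbon gives a 1.1-fold higher number from compound 2 to compound 3 (0.06 log units; within the scatter), so with the methyl present on the shared core, this swap produces no readable difference. The other single change, methyl in place of hydrogen on an aromatic carbon, gives a 6.7-fold higher number from compound 1 to compound 3 (0.83 log units; beyond the scatter), so among these steps only the methyl change moves the number beyond the scatter. Nothing available here explains either result.

It remains open whether the swap between propyl and 4-methoxyphenyl would also make no readable difference on the core without that methyl, since only one of those two groups is shown there. From the compounds shown here alone, how an amine or a longer chain at the propyl position would read also remains open.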